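Chain lengthening on the highest-reading core

A few compounds are considered here, and "the series" means these few. Any claim that something is new, unique, unknown or untested is made for them only; others in the source may bear on it.

Compound 1 (`CCCCCCCCn1c(N)c(N)c(=O)[nH]c1=O`) gives 620 nM in a functional assay (mitochondria, heart) with Bos taurus as the target (on this read-out lower numbers stand for stronger inhibition and higher numbers for weaker inhibition), and compound 2 (`CCCCCCCCCCn1c(N)c(N)c(=O)[nH]c1=O`) gives 280 nM on the same read-out. Compound 3 (`CCCCCCCCn1c(=O)[nH]c(=O)c2[nH]c(O)nc21`) sits at 28000 nM as the highest of the three numbers, beyond the scatter from both others, and its core differs from the one shared by the first two compounds.

Compound 4 (`CCCCCCCCCCn1c(=O)[nH]c(=O)c2[nH]c(O)nc21`) keeps the core of compound 3 and carries ethyl in place of hydrogen on a saturated chain carbon, eight bonds along the chain from an aromatic nitrogen. Going by the values given here, the same change has been measured only once, on the other core, so this single pair is the only guide. Going by a 2.2-fold lower number from compound 1 to compound 2 (0.35 log units; beyond the scatter) a modest step to a lower number is expected in this assay although no data yet show that it carries over to this core. The expected step is a 2.2-fold lower number from compound 3 to compound 4 (0.35 log units; beyond the scatter) on this estimate. Compound 4 is estimated at 12500 nM with an expected range from 5000 nM to 28000 nM on this read-out.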

Compound 4, half-maximal inhibitory concentration in the Bos taurus assay: 3700 nM
Beside the measured number, compound 4's estimate is 3.4-fold (0.53 log units) above it; measured number outside the range, below it.
By their numbers in the Bos taurus assay, from the lowest: compound 2; then compound 1; then compound 4; then compound 3.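

In the Bos taurus assay the ethyl in place of hydrogen, on a saturated chain carbon, eight bonds along the chain from an aromatic nitrogen, gives a 7.6-fold lower number from compound 3 to compound 4 (0.88 log units; beyond the scatter). The change thus lowers the number on both cores, and the earlier pair alone could not show that the size of the step differs between them: the same change on two cores in the Bos taurus assay, a 2.2-fold lower number (0.35 log units; beyond the scatter) from compound 1 to compound 2 and a 7.6-fold lower number (0.88 log units; beyond the scatter) from compound 3 to compound 4, 3.4-fold (0.53 log units) apart, beyond the scatter of two such steps. On the core of compound 3, the same change also raises the read-out of a physicochemical assay for lipophilicity; on this read-out lower numbers stand for lower lipophilicity and higher numbers for higher lipophilicity: the measured partition coefficient of compound 3, 1.1, and of compound 4, 2.04, a number 0.94 log units higher (beyond the scatter). In the physicochemical assay compound 3 gives 1.1 and compound 4 gives 2.04.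

From the compounds shown here alone, whether a longer chain, or an amine or a carboxylic acid in place of the ethyl, would lower the number further on either core stays open. With one pair on each core, the compounds shown also cannot tell whether the larger step on the core of compound 3 holds for other chain changes.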